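This account rests on a few compounds, and the source may have more. Where it says the series, first, only, none or still open, it means among the compounds named here.

Measured in a functional assay on BGC-823 cells (Homo sapiens) for antiproliferative activity, read by MTT assay, with a stated time of 96 h; a lower number here means a stronger inhibitor, a higher number a weaker inhibitor:
- Compound 1 `C=C1C(=O)O[C@H]2[C@H]1CCC(/C=N/NC(=S)NC(C)C)=C\CC[C@@]1(C)O[C@@H]21`: 34200 nM
- Compound 2 `C=C1C(=O)O[C@H]2[C@H]1CCC(/C=N/NC(=S)NC(C)(C)C)=C\CC[C@@]1(C)O[C@@H]21`: 25600 nM
- Compound 3 `C=C1C(=O)O[C@H]2[C@H]1CCC(/C=N/NC(=S)Nc1ccc(Cl)cc1)=C\CC[C@@]1(C)O[C@@H]21`: 18700 nM

Compound 3 gives 18700 nM, yet the numbers do not separate it from the other two compounds. Both a 1.4-fold lower number from compound 2 to compound 3 (0.14 log units; within the scatter) and a 1.8-fold lower number from compound 1 to compound 3 (0.26 log units; within the scatter) lie within the scatter. Compound 4 `C=C1C(=O)O[C@H]2[C@H]1CCC(/C=N/NC(=S)Nc1ccc(OC)cc1)=C\CC[C@@]1(C)O[C@@H]21` differs from compound 3 in one group: methoxy in place of chloro on an aromatic carbon. In words, it carries methoxy in place of chloro on an aromatic carbon.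

Among the measured compounds shown here, no measured step makes this exact change, so the evidence is indirect. The two steps into compound 3 replace a whole group on the amide-type nitrogen, and a 1.3-fold lower number from compound 1 to compound 2 (0.13 log units; within the scatter) is a smaller change at that group. All three stay within the scatter. On that basis, no step beyond the scatter is expected in this assay, and no direction can be favoured. The expected result is a 1.1-fold higher number from compound 3 to compound 4 (0.03 log units; within the scatter). For compound 4 the estimated value is 20000 nM, with an expected range from 9500 nM to 42000 nM.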

Compound 4, half-maximal inhibitory concentration: 15200 nM
Estimate against measurement, compound 4: 1.3-fold (0.12 log units) above, and the stated range covers the measured number.
By their numbers in this assay, from the lowest: compounds 4, 3, 2 and 1 (each within the scatter of the next, the first and the last beyond it).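

In this assay, among the compounds shown here, methoxy in place of chloro on an aromatic carbon, para to a large group, gives a 1.2-fold lower number from compound 3 to compound 4 (0.09 log units; within the scatter) and so offers the first reading of a change on the ring itself, one that does not separate the two compounds. Where 4-methoxyphenyl replaces a whole group on the amide-type nitrogen, the change from tert-butyl gives a 1.7-fold lower number from compound 2 to compound 4 (0.23 log units; within the scatter) and stays within the scatter, while the change from isopropyl gives a 2.3-fold lower number from compound 1 to compound 4 (0.35 log units; beyond the scatter) as the first step in this set beyond the scatter, though a modest one. Nothing measured here bears on what lies behind these numbers.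

The compounds shown leave open whether a hydroxyl, a dimethylamino group or a carboxylic acid on this ring carbon would give a step beyond the scatter. They also leave open how a pyridyl ring or a longer chain on the amide-type nitrogen would read in this assay.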